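Cathepsin S series: carboxy in place of methylsulfonylmethyl

This account rests on a few compounds, and the source may have more. Where it says the series, first, only, none or still open, it means among the compounds named here.

Measured so far:
compound 1, `COc1cccc(C(=O)N[C@@H](CCC2CCCCC2)C(=O)N[C@@H](CC(C)C)CN2CCc3cc(F)ccc32)c1`, 28 nM
compound 2, `COc1cccc(C(=O)N[C@@H](CC(C)(C)C)C(=O)N[C@@H](CCS(C)(=O)=O)CN2CCc3cc(F)ccc32)c1`, 14 nM

In an assay on isolated protein for inhibition of cathepsin S (Homo sapiens) (on this read-out higher numbers stand for weaker inhibition and lower numbers for stronger inhibition), compound 1 gives 28 nM, and in this assay compound 2 gives 14 nM. Compound 2 shows the lower of the two numbers, but compound 1 sits within the scatter of it, so the two cannot be told apart on this read-out. The two compounds also differ in more than one place, so no single step can be read from them.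

Compound 3, `COc1cccc(C(=O)N[C@@H](CC(C)(C)C)C(=O)N[C@@H](CC(=O)O)CN2CCc3cc(F)ccc32)c1`, has not yet been measured. It differs from compound 2 in one place: carboxy in place of (methylsulfonyl)methyl on a saturated chain carbon, two bonds along the chain from an amide-type nitrogen. Going by the values given here, no step between measured compounds covers this change, so the size and direction of the step are open. The expectation is a modest weakening, possibly no more than the scatter: the step from compound 2 to compound 3 is expected to be a 2.9-fold higher number from compound 2 to compound 3 (0.46 log units; beyond the scatter). For compound 3 in this assay the estimate is 40 nM, with a range from 10 nM to 160 nM.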

Compound 3, inhibition constant: 6 nM
The estimate for compound 3 lay 6.7-fold (0.82 log units) above the measured number; measured number outside the range, below it.
By their numbers in this assay, from the lowest: compound 3; then compounds 2 and 1 (each within the scatter of the next).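

In this assay, the series now has its first step that can be read at a single place: on a saturated chain carbon, two bonds along the chain from an amide-type nitrogen, carboxy in place of (methylsulfonyl)methyl gives a 2.3-fold lower number from compound 2 to compound 3 (0.37 log units; beyond the scatter), a modest change. This place therefore does not depend on the (methylsulfonyl)methyl group for inhibition of this enzyme; the smaller carboxy, with 3 heavy atoms against 5 and 1 hydrogen-bond donor against 0, is accepted and gives the lower number. No supporting measurement bears on why the step runs in this direction, so the counted differences between the two groups remain descriptions and not an explanation.

As far as these compounds go, it remains open whether a primary amide, a methyl ester or a longer chain ending in carboxy at the same place would hold or lower the number, which would show how far the step is specific to carboxy. From the compounds shown here alone, it is also open whether the same change carries over to the different side chain of compound 1, since this single step was read only on the side chain shared by compound 2 and compound 3.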